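The source may report more compounds than this note shows. Statements on the series, on what has been measured and on what is new or still open speak of the compounds shown alone.

Compound 1 `N=C(S)CCn1ncccc1=O` gives > 100 mg/kg in a functional assay on the whole organism (stomach) with Rattus norvegicus as the target (a higher number here means that more compound is needed for the effect, a lower number that less compound is needed), a limit of the assay.
Compound 2 `CC(CC(=N)S)n1ncccc1=O` gives > 100 mg/kg in this assay, also a limit.
Compound 3 `C/N=C(\S)CCn1ncccc1=O` gives > 100 mg/kg in this assay, again a limit.

Compound 3 therefore stands nowhere in particular on the numbers shown: its value is only a limit, and the other two values it could be set against are limits as well, as noted in the limit of > 100 mg/kg in this assay, at which 3 of the 3 values shown sit. The piece now follows the change to compound 4 `C/N=C(\S)CC(C)n1ncccc1=O`, which differs from compound 3 by methyl in place of hydrogen on a saturated chain carbon bound to an aromatic nitrogen and a saturated chain carbon. Among the measured steps, the one from compound 1 to compound 2 carries the same change and bears on it directly, but its size is a step that the two limits leave unreadable from compound 1 to compound 2. The step from compound 1 to compound 3 is likewise a step that the two limits leave unreadable from compound 1 to compound 3. Among the compounds with values here, no measured step gives a readable size, so no step beyond the scatter is expected in either direction in this assay, and the step from compound 3 to compound 4 is estimated at a step that the limit leaves unreadable from compound 3 to compound 4. Compound 4 is accordingly expected to give about 150 mg/kg in this assay, within a range from 60 mg/kg to 500 mg/kg, most likely again as a limit rather than a number.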

Compound 4, dose for half-maximal effect: > 100 mg/kg
Compound 4 was reported as a limit; the forecaster's own chance of this, stated with the estimate: 80%; the middle value lies beyond the limit too.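

Compound 4 is a limit, so neither its step from compound 3 nor its step from compound 2 can be read in this assay: the limit of > 100 mg/kg in this assay, at which 4 of the 4 values shown sit.

The compounds shown leave open whether methyl in place of hydrogen changes the dose needed at all, and how much compound any of them requires for the effect.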